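This account rests on a few compounds, and the source may have more. Where it says the series, first, only, none or still open, it means among the compounds named here.

Measured so far:
compound 1 `CC(=O)N1CCN([C@H]2CC[C@H](Nc3ncnn4ccc([C@H]5CC[C@H](C(N)=O)CC5)c34)CC2)CC1` — 1.4
compound 2 `CN(C)[C@H]1CC[C@H](Nc2ncnn3ccc([C@H]4CC[C@H](C(N)=O)CC4)c23)CC1` — 0.2

Going by the values given here, in a physicochemical assay for lipophilicity, using the shake flask method, at pH 7.4 (a higher number here means a more lipophilic compound, a lower number a more polar compound), compound 1 stands highest of the two numbers; the one measured step, a number 1.20 log units lower from compound 1 to compound 2 (beyond the scatter), lies beyond the scatter. Compound 3 `CC(=O)N1CCN([C@H]2CC[C@H](Nc3ncnn4ccc(C(C)C)c34)CC2)CC1` is not yet measured. It differs from compound 1 in one place: isopropyl in place of 4-carbamoylcyclohexyl on an aromatic carbon. No measured step touches this position; the single step shown changes a saturated ring carbon elsewhere and offers no direct guide. Since a group with one hydrogen-bond donor and one hydrogen-bond acceptor gives way to isopropyl, which has none, a rise in this assay beyond the scatter is expected, a number 0.60 log units higher from compound 1 to compound 3 (beyond the scatter). Compound 3 is estimated at 2, within 1.3 to 2.7.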

Compound 3, distribution coefficient: 2.4
Estimate against measurement, compound 3: 0.40 log units below; low and high end bracket the measured number.
By their numbers in this assay, from the lowest: compound 2; then compound 1; then compound 3.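

Placing isopropyl instead of 4-carbamoylcyclohexyl on this aromatic carbon gives, in this assay, a number 1.00 log units higher from compound 1 to compound 3 (beyond the scatter), the first sign that this position also moves the read-out. The swap changes the ring, the heavy-atom count and the hydrogen-bond donors and acceptors all at once, so these cannot be told apart. No measured evidence here accounts for the size of the step. The compounds shown leave open how a plain cyclohexyl, without the carbamoyl group, would read in this assay. That group would separate the ring from the carbamoyl.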